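Working notes: lengthening the methoxy-ended side chain

A few compounds are considered here, and "the series" means these few. Any claim that something is new, unique, unknown or untested is made for them only; others in the source may bear on it.

Measured so far in a physicochemical assay for solubility, using the shake flask method, in phosphate buffer, with a stated time of 24 h, at pH 6.8; on this read-out lower numbers stand for lower solubility and higher numbers for higher solubility:
- compound 1 `COc1cc(/C=C/C(=O)/C=C(/C=C/c2ccc(O)c(OC)c2)NCCO)ccc1O` gives 11800 nM
- compound 2 `COc1cc(/C=C/C(=O)/C=C(/C=C/c2ccc(O)c(OC)c2)NCCCO)ccc1O` gives 56300 nM
- compound 3 `COCCNC(=C\C(=O)/C=C/c1ccc(O)c(OC)c1)/C=C/c1ccc(O)c(OC)c1` gives 12700 nM

Compound 3 stands at 12700 nM and the step of a 1.1-fold higher number from compound 1 to compound 3 (0.03 log units; within the scatter) places it level with compound 1. Compound 2 is the highest of the three, with a 4.4-fold lower number from compound 2 to compound 3 (0.65 log units; beyond the scatter) as the measured step.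

The next compound, compound 4 `COCCCNC(=C\C(=O)/C=C/c1ccc(O)c(OC)c1)/C=C/c1ccc(O)c(OC)c1`, carries methoxymethyl in place of methoxy on a saturated chain carbon, two bonds along the chain from an amine nitrogen.

Among the compounds with values here, the closest precedent is compound 2, where hydroxymethyl in place of hydroxy at that same place gave a 4.8-fold higher number from compound 1 to compound 2 (0.68 log units; beyond the scatter). Within the data shown here, no measured pair shows this lengthening on a methoxy-ended chain, so that single step is only a guide. A modest rise is therefore expected, smaller than the precedent, and no change beyond the scatter remains possible.

The expected outcome in this assay is a 2.4-fold higher number from compound 3 to compound 4 (0.37 log units; beyond the scatter). For compound 4 the estimated value is 30000 nM, with an expected range of 11000 nM to 70000 nM.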

Compound 4, solubility: 9660 nM
Compound 4: the middle estimate sits 3.1-fold (0.49 log units) above what was measured; measured number below the stated range.
By their numbers in this assay, from the lowest: compounds 4, 1 and 3 (each within the scatter of the next); then compound 2.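

In this assay, going from (2-methoxyethyl)amino to (3-methoxypropyl)amino gives a 1.3-fold lower number from compound 3 to compound 4 (0.12 log units; within the scatter) and so does not reproduce the clear step seen with the hydroxy-ended chains, a 4.8-fold higher number from compound 1 to compound 2 (0.68 log units; beyond the scatter) for the same lengthening. Methyl in place of hydrogen on the chain-end oxygen now also reads differently with chain length: a 1.1-fold higher number from compound 1 to compound 3 (0.03 log units; within the scatter) on the shorter chain, but a 5.8-fold lower number from compound 2 to compound 4 (0.77 log units; beyond the scatter) on the longer one, while a 1.2-fold lower number from compound 1 to compound 4 (0.09 log units; within the scatter) leaves compound 4 level with compound 1, so that compound 2 alone stands apart from the other three. No supporting data bear on why the two chain ends differ here.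

On these data alone, all of this rests on a single longer-chain pair, so it remains open whether a 4-methoxybutyl or 4-hydroxybutyl chain would follow compound 2 or compound 4. Also open, as far as these compounds go, is how an amine or a carboxylic acid at the chain end would read in this assay on this core.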